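A Bridged Bicyclic Amine Replaces a Dimethylpiperazine

This account rests on a few compounds, and the source may have more. Where it says the series, first, only, none or still open, it means among the compounds named here.

Of the compounds shown here, three built on a shared core have been tested. Compound 1 `c1cnc2c(c1)CCC[C@@H]2N(CC1CC1)C[C@H]1Cc2c(cccc2N2CCNCC2)CN1` gives 26.7 nM in a functional assay on CCRF-CEM cells for antagonist activity at C-X-C chemokine receptor type 4 (Homo sapiens), read by calcium flux, with stated times of 25 min and 90 s; on this read-out lower numbers stand for stronger inhibition and higher numbers for weaker inhibition. Compound 3 `CN(C[C@@H]1Cc2c(cccc2N2CCNCC2)CN1)[C@H]1CCCc2cccnc21` gives 313 nM in this assay. Compound 2 `C[C@@H]1CN(c2cccc3c2C[C@H](CN(C)[C@H]2CCCc4cccnc42)NC3)C[C@H](C)N1` gives 61 nM in this assay and so stands second highest of the three: its nearest neighbour, compound 1, has a lower number, and the gap lies beyond the scatter; its furthest neighbour, compound 3, has a higher number, also beyond the scatter.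

Compound 4 `CN(C[C@H]1Cc2c(cccc2N2C[C@H]3C[C@@H]2CN3)CN1)[C@H]1CCCc2cccnc21` is not yet measured. Compared with compound 2, its difference is a group of 7 heavy atoms (5 carbon, 2 nitrogen; 2 five-membered non-aromatic rings with 1 hetero atom each) in place of a group of 8 heavy atoms (6 carbon, 2 nitrogen; one six-membered non-aromatic ring with 2 hetero atoms), on an aromatic carbon. Among the measured compounds shown here, no measured pair shows this exact change, so the step can only be judged from what compound 2 and its neighbours show. A modest step is expected, with the number for compound 4 drifting upward: the estimated step is a 1.6-fold higher number from compound 2 to compound 4 (0.21 log units; within the scatter) in this assay, roughly at the edge of the scatter. Compound 4 is therefore estimated to give 100 nM in this assay, within a range from 35 nM to 300 nM.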

Compound 4, half-maximal inhibitory concentration: 20.7 nM
For compound 4 the middle estimate is 4.8-fold (0.68 log units) above the measured one, and the stated range ends above it.
By their numbers in this assay, from the lowest: compounds 4 and 1 (each within the scatter of the next); then compound 2; then compound 3.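

In this assay, placing the bridged bicyclic amine on this aromatic carbon in place of the 3,5-dimethylpiperazin-1-yl group gives a 2.9-fold lower number from compound 2 to compound 4 (0.47 log units; beyond the scatter). This position therefore accepts a group of 7 heavy atoms with 2 five-membered non-aromatic rings in place of a single six-membered ring, and the number improves rather than worsens. Both groups carry 1 hydrogen-bond donor and 2 hydrogen-bond acceptors, so those counts do not separate them, and nothing measured here accounts for the gain.

The compounds shown leave open whether the bridged group with its two stereocentres reversed would match compound 4, and how a morpholine would fare on this aromatic carbon. They also do not tell whether the gain carries over to compound 1, whose amine bears a cyclopropylmethyl group rather than a methyl.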